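Compound 4: Another Limit Expected

This account rests on a few compounds, and the source may have more. Where it says the series, first, only, none or still open, it means among the compounds named here.

In an ADME assay on HepG2 cells (Homo sapiens) for cytotoxicity, read by CellTiter-Glo and resazurin assay, with a stated time of 72 h (a higher number here means that more compound is needed for the effect, a lower number that less compound is needed), compound 1 (`CC(C)N(Cc1cccc(OCCCCCC(=O)O)c1)C(=O)c1ccc(-c2ccncc2)cc1`) gives > 26000 nM as a limit of the assay and not a number. Compound 2 (`CCOc1cccc(-c2ccc(C(=O)N(Cc3cccc(OCCCCCC(=O)O)c3)C(C)C)cc2)c1`) gives > 20800 nM as a limit too. Compound 3 (`CC(C)N(Cc1cccc(OCCCCCC(=O)O)c1)C(=O)c1ccc(-c2c[nH]c3ccccc23)cc1`) gives > 26000 nM as a limit as well, so it stands at the limit of > 26000 nM in this assay, at which 2 of the 3 values shown sit, and has no number of its own. Going to compound 4 (`CC(C)N(Cc1cccc(OCCCCCC(=O)O)c1)C(=O)c1ccc(-c2cccc(S(C)(=O)=O)c2)cc1`) puts 3-(methylsulfonyl)phenyl in place of 1H-indol-3-yl on an aromatic carbon, counted as 3-(methylsulfonyl)phenyl in place of 1H-indol-3-yl on an aromatic carbon in full. Three swaps at this place bear on it: a step that the two limits leave unreadable from compound 1 to compound 3 and a step that the two limits leave unreadable from compound 2 to compound 3 and a step that the two limits leave unreadable from compound 1 to compound 2 and none offers a size. No change beyond the scatter is therefore expected in this assay so a step that the limit leaves unreadable from compound 3 to compound 4 is estimated as small, with no firm direction. Compound 4 is estimated at 30000 nM with a range of 18000 nM to 50000 nM and is expected to be reported as a limit again.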

Compound 4, half-maximal effective concentration: > 26000 nM
Compound 4 gave a limit, no number (the forecaster's own chance of this, stated with the estimate: 85%); the middle value is on the limit's open side.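

Compound 4, like compound 1, compound 2 and compound 3, gives only a limit in this assay, so its steps to those three compounds cannot be read. The compounds shown leave open whether any of these groups changes the half-maximal effective concentration at all.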